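The source may hold more compounds than are shown below. What is called first, only, known or untested is meant among the compounds shown, and "the series" means these compounds.

Compounds 1 and 2 share one core and differ only in the group on the sulfonyl sulfur. In an assay on CHO cells for displacement of a labelled ligand from prostaglandin D2 receptor 2 (Homo sapiens), read by scintillation counting (a lower number here means a stronger inhibitor, a higher number a weaker inhibitor), compound 1 `Cc1ccc(S(=O)(=O)Cc2ccccc2)cc1C#Cc1cc(Cl)ccc1OCC(=O)O` gives 5 nM. In this assay compound 2 `Cc1ccc(S(=O)(=O)CC(C)C)cc1C#Cc1cc(Cl)ccc1OCC(=O)O` gives 3 nM, the lower of the two numbers, although a 1.7-fold lower number from compound 1 to compound 2 (0.22 log units; within the scatter) lies within the scatter. Compound 3 `Cc1ccc(S(=O)(=O)N(C)C)cc1C#Cc1cc(Cl)ccc1OCC(=O)O` differs from compound 2 by dimethylamino in place of isobutyl on a sulfonyl sulfur. For the measured compounds named here, the one measured step at this position, from compound 1 to compound 2, stayed within the scatter, so no step beyond the scatter is expected in this assay. Compound 3 is therefore estimated at 5 nM, within 1.5 nM to 16 nM. That amounts to an expected step of a 1.7-fold higher number from compound 2 to compound 3 (0.22 log units; within the scatter).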

Compound 3, inhibition constant: 5 nM
Estimate against measurement, compound 3: no gap at the digits printed; low and high end bracket the measured number.
By their numbers in this assay, from the lowest: compounds 2, 1 and 3 (each within the scatter of the next).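

In this assay the change to dimethylamino gives a 1.7-fold higher number from compound 2 to compound 3 (0.22 log units; within the scatter) and no change at the digits printed from compound 1 to compound 3 (within the scatter) when benzyl is the group replaced. This position on the sulfonyl sulfur therefore accepts a group attached through nitrogen as well as one attached through carbon, and isobutyl, benzyl and dimethylamino cannot be told apart by these numbers. Going by these compounds, whether a ring amine such as piperidine, or a chain ending in a carboxylic acid, would read the same stays open. Nothing available explains why these three groups read alike.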